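The source may hold more compounds than are shown below. What is called first, only, known or untested is meant among the compounds shown, and "the series" means these compounds.

Measured compounds:
compound 1, `CC(=O)Nc1nc(CN=C=S)cs1`, 5200 nM;
compound 2, `CCC(=O)Nc1nc(CN=C=S)cs1`, 6800 nM;
compound 3, `CC(=O)Nc1nc(CN=C=S)c[se]1`, 30000 nM.

In a functional assay on L1210 cells (Mus musculus) for antiproliferative activity (a higher number here means a weaker inhibitor, a lower number a stronger inhibitor), compound 1 gives 5200 nM and compound 2 gives 6800 nM. The change between them, (methyl in place of hydrogen on a saturated chain carbon bound to a carbonyl carbon), made a step of a 1.3-fold higher number from compound 1 to compound 2 (0.12 log units; within the scatter). Compound 3 differs from compound 1 in its core; that difference between the two cores is not broken down here, and compound 3 gives 30000 nM.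

Compound 4, `CCC(=O)Nc1nc(CN=C=S)c[se]1`, has not been measured. It differs from compound 3 by methyl in place of hydrogen on a saturated chain carbon bound to a carbonyl carbon, the same change as from compound 1 to compound 2; among the compounds shown it occurs twice. In this assay the step from compound 3 to compound 4 is expected to be small, a 1.3-fold higher number from compound 3 to compound 4 (0.10 log units; within the scatter), resting on the step from compound 1 to compound 2 of a 1.3-fold higher number from compound 1 to compound 2 (0.12 log units; within the scatter). Compound 4 is therefore estimated at 38000 nM, between 20000 nM and 75000 nM.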

Compound 4, half-maximal inhibitory concentration: 3500 nM
Compound 4: the middle estimate sits 11-fold (1.04 log units) above what was measured; measured number below the stated range.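

In this assay, methyl in place of hydrogen on a saturated chain carbon bound to a carbonyl carbon gave an 8.6-fold lower number from compound 3 to compound 4 (0.93 log units; beyond the scatter) and so did not repeat on the core of compound 3 what it had done on the core of compound 1. The two steps differ: the same change on two cores in this assay, a 1.3-fold higher number (0.12 log units; within the scatter) from compound 1 to compound 2 and an 8.6-fold lower number (0.93 log units; beyond the scatter) from compound 3 to compound 4, 11-fold (1.05 log units) apart, beyond the scatter of two such steps. This shows that in this series the step measured on one core could not be carried over to the other, but with a single pair on each core it does not show why, or how the change would behave on any further core.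

The compounds shown leave open whether a longer chain than propanoyl would separate the two cores again. They also leave open whether an amine on that chain would do so.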